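The compounds below may be only part of what the source reports. "The series", "measured", "known", "first", "only" and "open" are said of these compounds alone.

Three compounds share one core and differ only in the aryl group on a carbonyl carbon: compound 1 `CN(C(=O)NC(=O)c1cccc(C(F)(F)F)c1)c1nc(C(F)(F)F)c(C(=O)N/N=C/c2ccccc2C(F)(F)F)s1`, compound 2 `CN(C(=O)NC(=O)c1ccc(F)c(F)c1)c1nc(C(F)(F)F)c(C(=O)N/N=C/c2ccccc2C(F)(F)F)s1` and compound 3 `CN(C(=O)NC(=O)c1ccc(Cl)cc1Cl)c1nc(C(F)(F)F)c(C(=O)N/N=C/c2ccccc2C(F)(F)F)s1`. In a functional assay on A549 cells (Homo sapiens) for inhibition, read by MTT assay, with a stated time of 72 h (on this read-out lower numbers stand for stronger inhibition and higher numbers for weaker inhibition), compound 1 gives 12.1 ug/mL, compound 2 gives 6.96 ug/mL and compound 3 gives 15.3 ug/mL. Compound 3 therefore stands highest of the three numbers, though its separation from compound 1 is small, as the step of a 1.3-fold higher number from compound 1 to compound 3 (0.10 log units; within the scatter) shows, while the step of a 2.2-fold higher number from compound 2 to compound 3 (0.34 log units; beyond the scatter) is modest and the step of a 1.7-fold lower number from compound 1 to compound 2 (0.24 log units; within the scatter) is small. The fourth compound, compound 4 `CN(C(=O)NC(=O)c1c(Cl)cccc1Cl)c1nc(C(F)(F)F)c(C(=O)N/N=C/c2ccccc2C(F)(F)F)s1`, is not yet measured; it carries 2,6-dichlorophenyl in place of 2,4-dichlorophenyl on a carbonyl carbon. Among the measured compounds shown here, none of the measured steps moves chlorine around a ring in this way, but all three swaps of the aryl group on this carbonyl carbon gave small movements in this assay. Compound 4 is thus expected to sit close to compound 3, with an expected step of a 1.0-fold lower number from compound 3 to compound 4 (0.01 log units; within the scatter) of no clear direction beyond the scatter. The estimate for compound 4 in this assay is 15 ug/mL, ranging from 7 ug/mL to 32 ug/mL.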

Compound 4, half-maximal inhibitory concentration: 12 ug/mL
Estimate against measurement, compound 4: 1.3-fold (0.10 log units) above, and the stated range covers the measured number.
By their numbers in this assay, from the lowest: compounds 2, 4, 1 and 3 (each within the scatter of the next, the first and the last beyond it).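

Rearranging the same atoms on the carbonyl carbon, from 2,4-dichlorophenyl to 2,6-dichlorophenyl, is a change the earlier compounds did not include, and in this assay it gives a 1.3-fold lower number from compound 3 to compound 4 (0.11 log units; within the scatter). The new aryl group also cannot be separated from the two others, with a 1.0-fold lower number from compound 1 to compound 4 (0.00 log units; within the scatter) and a 1.7-fold higher number from compound 2 to compound 4 (0.24 log units; within the scatter), so compound 4 lies within the scatter of all three earlier compounds, and the step from compound 2 to compound 3 remains the only one beyond it. No measurement is available here that would account for these small differences.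

The compounds shown leave open whether an amine or a carboxylic acid on this aryl group, or a plain alkyl chain in its place on the carbonyl carbon, would move the number beyond the scatter. They also leave open whether this flat picture holds in other cell lines.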